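Methyl Added to Compound 2: Expected Inhibition

A few compounds are considered here, and "the series" means these few. Any claim that something is new, unique, unknown or untested is made for them only; others in the source may bear on it.

Measured compounds:
compound 1 `CC(c1ccc(-c2cccc3ccccc23)nc1)n1ccnc1` gives 60 nM
compound 2 `c1ccc(-c2ccc(Cc3cccnc3)cn2)cc1` gives 32 nM
compound 3 `c1ccc(-c2ccc(Cc3ccncc3)cn2)cc1` gives 98 nM

These three values come from an in vitro assay on V79MZh cells for inhibition of cytochrome P450 11B1, mitochondrial (Homo sapiens); on this read-out higher numbers stand for weaker inhibition and lower numbers for stronger inhibition. Compound 2 has the lowest number of the three; compound 1 lies within the scatter of it, while compound 3 sits beyond, at a 3.1-fold higher number from compound 2 to compound 3 (0.49 log units; beyond the scatter). Compound 4 `Cc1ccncc1Cc1ccc(-c2ccccc2)nc1` differs from compound 2 by methyl in place of hydrogen on an aromatic carbon, a methyl in place of hydrogen on an aromatic carbon, ortho to a large group and opposite the ring nitrogen. For the measured compounds named here, no measured step involves a methyl added in this way; the only step known, from compound 2 to compound 3, concerns the attachment point of the ring rather than a substituent on it. Therefore no shift beyond the scatter is expected in this assay, with an estimated step of a 1.3-fold higher number from compound 2 to compound 4 (0.10 log units; within the scatter). Compound 4 is estimated at 40 nM, between 15 nM and 130 nM.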

Compound 4, half-maximal inhibitory concentration: 8 nM
Estimate against measurement, compound 4: 5.0-fold (0.70 log units) above, and the stated range ends above it.
By their numbers in this assay, from the lowest: compound 4; then compounds 2, 1 and 3 (each within the scatter of the next, the first and the last beyond it).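

In this assay, a methyl in place of hydrogen on an aromatic carbon, ortho to a large group and opposite the ring nitrogen, gives a 4.0-fold lower number from compound 2 to compound 4 (0.60 log units; beyond the scatter). This shows that this ring carbon can take a substituent with a shift beyond the scatter toward stronger inhibition, whereas the earlier step, a 3.1-fold higher number from compound 2 to compound 3 (0.49 log units; beyond the scatter), changed only the ring's attachment point and went the other way. No evidence here accounts for the methyl step. On these data alone, whether an ethyl, a methoxy group or a chlorine at this carbon would give a similar step remains open, as does the effect of a methyl on the other ring carbons.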